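The compounds below may be only part of what the source reports. "The series", "measured", "known", "first", "only" and "open" are said of these compounds alone.

Compound 3 `C[C@@H](Cn1c(=O)[nH]/c(=N\c2ccc(Oc3cccc(F)n3)cc2)n(Cc2ccc(Cl)cc2)c1=O)C(=O)O` gives 60% in an ADME assay on the whole organism (Rattus norvegicus) for pharmacokinetics, using cassette dosing, at a dose of 1 mg/kg by the oral route (on this read-out lower numbers stand for lower oral bioavailability and higher numbers for higher oral bioavailability), the highest of the three numbers seen so far. Compound 2 `C[C@@H](Cn1c(=O)[nH]/c(=N\c2ccc(Oc3nccs3)cc2)n(Cc2ccc(Cl)cc2)c1=O)C(=O)O` gives 41.4% in this assay, and compound 1 `CC(C)Oc1ccc(Nc2nc(=O)n(CCCO)c(=O)n2Cc2ccc(Cl)cc2)cc1Cl` gives 36.2%. Among the measured compounds shown here, the only change measured between close relatives is a number 18.6 percentage points higher from compound 2 to compound 3 (beyond the scatter). Compound 4 `C[C@@H](Cn1c(=O)[nH]/c(=N\c2ccc(Oc3ccsn3)cc2)n(Cc2ccc(Cl)cc2)c1=O)C(=O)O` differs from compound 3 in one place: 1,2-thiazol-3-yl in place of 6-fluoropyridin-2-yl on an oxygen on an aromatic ring. That change runs much like the reverse of the step from compound 2 to compound 3, since a five-membered ring with two hetero atoms again replaces the fluoropyridine. A drop of similar size is therefore expected, a number 16 percentage points lower from compound 3 to compound 4 (beyond the scatter). Compound 4 is estimated at 44%, with a range from 30% to 60%.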

Compound 4, oral bioavailability: 87.6%
Compound 4: middle estimate off by 43.6 percentage points, on the low side; the measured number lies above the stated range.
By their numbers in this assay, from the lowest: compounds 1 and 2 (each within the scatter of the next); then compound 3; then compound 4.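

The step of a number 27.6 percentage points higher from compound 3 to compound 4 (beyond the scatter) runs against the fall that the step from the fluoropyridine to the other five-membered ring had suggested, so ring size alone does not set the outcome in this assay at this position. The two thiazoles differ widely, with a number 46.2 percentage points higher from compound 2 to compound 4 (beyond the scatter), so the arrangement of the ring's hetero atoms matters here. Nothing measured explains this difference. Still open, going by these compounds, is how a methyl group or an amine on the 1,2-thiazol-3-yl ring would change the number.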